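Chloro for hydrogen on the phenyl of compound 2

The source may report more compounds than this note shows. Statements on the series, on what has been measured and on what is new or still open speak of the compounds shown alone.

Compound 2 `c1ccc(-c2nc3sc(-c4ccccc4)cn3n2)cc1` serves as the reference point. In a functional assay on MCF7 cells (Homo sapiens) for inhibition, read by sulforhodamine B assay, with a stated time of 48 h, tested at 10 uM (on this read-out higher numbers stand for more inhibition of growth at the one concentration tested and lower numbers for less inhibition of growth), compound 2 gives 61%, the highest of the three numbers in hand. Compound 3 `COc1cc(-c2nc3sc(-c4ccccc4)cn3n2)cc(OC)c1OC` gives 23%, a number beyond the scatter below that of compound 2; compound 1 `C/C(=N\O)c1ccc(NC(=O)Cn2nc(-c3ccc(Cl)cc3)nc2N)cc1` gives 15.9%, further down still and also beyond the scatter. Among the measured compounds shown here, no two measured compounds differ in a single place, so no step is known from the measured set. Compound 4 `Clc1ccc(-c2cn3nc(-c4ccccc4)nc3s2)cc1` remains to be measured; it differs from compound 2 by chloro in place of hydrogen on an aromatic carbon. For the measured compounds named here, with no comparable step to lean on, the expected step of a number 6 percentage points lower from compound 2 to compound 4 (within the scatter) is estimated to be of modest size, in either direction, or none beyond the scatter. Compound 4 is expected to give 55%, within a range of 30% to 78%.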

Compound 4, percent growth inhibition at one concentration: 35%
For compound 4 the middle estimate is 20 percentage points above the measured one; the measured number falls inside the stated range.
By their numbers in this assay, from the lowest: compounds 1 and 3 (each within the scatter of the next); then compound 4; then compound 2.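

In this assay, among the compounds shown here, the change from phenyl to 4-chlorophenyl provides the first single-place comparison: a number 26 percentage points lower from compound 2 to compound 4 (beyond the scatter). This position on the phenyl ring is therefore not indifferent to substitution, as one chlorine atom in place of hydrogen moves the read-out beyond the scatter. No measurement offered here accounts for this step. Going by these compounds, whether the drop is specific to chloro or extends to other groups at this position remains open. Fluoro, an amine or a hydroxyl group here would test this, and chloro on the other phenyl ring would show whether the step depends on the ring carrying it.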